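Cycloheptyl for cyclopentyl on the ring amine of compound 1

The compounds below may be only part of what the source reports. "The series", "measured", "known", "first", "only" and "open" are said of these compounds alone.

Compound 1 `N#C[C@@]1(NC(=O)[C@@H](CC(=O)N2CCOCC2)CC2CCCCC2)CCN(C2CCCC2)C1` gives 75 nM in an assay on isolated protein for inhibition of cathepsin S (Homo sapiens) (a lower number here means a stronger inhibitor, a higher number a weaker inhibitor), the lowest of the two numbers recorded; compound 2 `N#C[C@H](CCc1ccccc1)NC(=O)[C@@H](CC(=O)N1CCOCC1)CC1CCCCC1` gives 171 nM in this assay, a gap beyond the usual scatter. Compound 3 `N#C[C@@]1(NC(=O)[C@@H](CC(=O)N2CCOCC2)CC2CCCCC2)CCN(C2CCCCCC2)C1` has not yet been measured. It differs from compound 1 in one place: cycloheptyl in place of cyclopentyl on an amine nitrogen in a ring. Among the compounds with values here, no measured pair shows what such a change does, so the step of a 1.2-fold higher number from compound 1 to compound 3 (0.08 log units; within the scatter) is expected to be small, in no sure direction, and probably within the scatter. Compound 3 is therefore estimated at 90 nM, between 30 nM and 300 nM.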

Compound 3, half-maximal inhibitory concentration: 23 nM
Beside the measured number, compound 3's estimate is 3.9-fold (0.59 log units) above it, and the stated range ends above it.
By their numbers in this assay, from the lowest: compound 3; then compound 1; then compound 2.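

On the amine nitrogen in a ring, the compounds up to now gave no sign of how this position responds to a change of carbon ring. In this assay cycloheptyl in place of cyclopentyl gives a 3.3-fold lower number from compound 1 to compound 3 (0.51 log units; beyond the scatter) and so shows that the position is sensitive to this change, with the seven-membered ring giving the lower number. No measured evidence on hand accounts for this step. From the compounds shown here alone, a single step defines no trend, so it stays open whether cyclohexyl would fall between the two compounds. Going by these compounds, whether cyclooctyl or a phenyl group would lower the number further also remains unknown.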